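The source may report more compounds than this note shows. Statements on the series, on what has been measured and on what is new or still open speak of the compounds shown alone.

Values measured in an ADME assay on microsomes from liver (Homo sapiens) for metabolic stability, using NADPH, with a stated time of 40 min, tested at 2 uM; on this read-out lower numbers stand for a shorter-lived compound and higher numbers for a longer-lived compound:
- Compound 1 `CNC(=O)c1cccc2nc(-c3c[nH]c4c(C)cccc34)ccc12` gives 0.983 h
- Compound 2 `Fc1ccc2c(-c3ccc4ccccc4n3)c[nH]c2c1Cl` gives 0.183 h
- Compound 3 `Fc1ccc2c(-c3ccc4ccccc4n3)c[nH]c2c1F` gives 0.167 h

Compound 3 and compound 2 sit within the scatter of each other, and the values show both well short of compound 1. The next compound to consider is compound 4 `Cc1ccc2c(-c3ccc4ccccc4n3)c[nH]c2c1F`, which comes from compound 3 by a single swap: methyl in place of fluoro on an aromatic carbon. In plain terms, this is methyl in place of fluoro on an aromatic carbon.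

Among the compounds with values here, only one measured step compares two compounds that differ in one place: a 1.1-fold lower number from compound 2 to compound 3 (0.04 log units; within the scatter). That swap of fluoro in place of chloro concerns a different carbon and stays within the scatter, so it offers only weak guidance. Compound 1 also carries a methyl group, but it differs from compound 3 in more than one place, so its longer half-life cannot be credited to methyl. Within the data shown here, no measured step shows methyl replacing fluoro, so the expectation in this assay is for no step beyond the scatter. The estimated step is small: a 1.0-fold lower number from compound 3 to compound 4 (0.02 log units; within the scatter). For compound 4 the expected half-life is 0.16 h, with an estimated range from 0.08 h to 0.33 h.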

Compound 4, half-life: 0.25 h
For compound 4 the middle estimate is 1.6-fold (0.19 log units) below the measured one; low and high end bracket the measured number.
By their numbers in this assay, from the lowest: compounds 3, 2 and 4 (each within the scatter of the next); then compound 1.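

In this assay, methyl in place of fluoro on this aromatic carbon gives a 1.5-fold higher number from compound 3 to compound 4 (0.18 log units; within the scatter). Within the data shown here, this is the first view of a change at this carbon, which is ortho to a fluoro group, since the earlier step between compound 2 and compound 3 concerned a different carbon; it shows that, on this read-out, the two groups cannot be told apart here, as the difference is no larger than repeat measurements of one compound would be expected to give. No measured evidence is available to explain this result.

Among the compounds that share this core, this carbon carries only fluoro or methyl, so it remains open whether a different kind of group here, such as an amine, a carboxylic acid or a longer chain, would move the half-life beyond the scatter. Also open, on these data alone, is whether methyl would give the same result in another setting, for example with chloro rather than fluoro on the neighbouring position named in the step from compound 2 to compound 3.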